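The source may hold more compounds than are shown below. What is called first, only, known or untested is meant among the compounds shown, and "the series" means these compounds.

Series notes. In an ADME assay on HeLa cells (Homo sapiens) for cytotoxicity, read by ATP content, with a stated time of 3 days (a higher number here means that more compound is tolerated, a lower number that less compound is tolerated), compound 1 `N#CCCCn1c(Cn2c(=O)n(-c3ccncc3F)c3ccncc32)cc2cc(Cl)ccc21` reaches only the limit of the assay, > 50000 nM. Compound 2 `N#CCCCn1c(Cn2c(=O)n(-c3ccc(C(=O)O)cc3)c3ccncc32)cc2cc(Cl)ccc21` likewise reaches only the limit of the assay, > 50000 nM. The step that the two limits leave unreadable from compound 1 to compound 2 therefore stays unreadable, since (the limit of > 50000 nM in this assay, at which 2 of the 2 values shown sit). Compound 2 thus stands at the limit and nowhere else among the numbers shown in this assay.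

Compound 3 `COc1ccc(-n2c(=O)n(Cc3cc4cc(Cl)ccc4n3CCCC#N)c3cnccc32)cc1C` has not yet been measured in this assay. Its change from compound 2 is 4-methoxy-3-methylphenyl in place of 4-carboxyphenyl on an aromatic nitrogen. Among the measured compounds shown here, the only measured step on this aromatic nitrogen, from compound 1 to compound 2, has no readable size, so no step beyond the scatter is expected here. The expected step in this assay is a number no higher from compound 2 to compound 3 (the limit leaves the size open). The estimate for compound 3 in this assay is 50000 nM, with a range from 20000 nM to 100000 nM, and a limit rather than a number is the most likely outcome.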

Compound 3, half-maximal cytotoxic concentration: > 50000 nM
Compound 3 ended at the assay's limit; the forecaster's own chance of this, stated with the estimate: 70%; the middle value sits exactly at the limit.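

No step can be read among compound 1, compound 2 and compound 3 in this assay, since each value is a limit and not a number: the limit of > 50000 nM in this assay, at which 3 of the 3 values shown sit.

The compounds shown leave open whether 3-fluoropyridin-4-yl, 4-carboxyphenyl and 4-methoxy-3-methylphenyl on the aromatic nitrogen differ at all in half-maximal cytotoxic concentration.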